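The source may report more compounds than this note shows. Statements on the series, on what has been measured and on what is new or still open speak of the compounds shown alone.

Measured compounds:
- compound 1 `Cc1ccc(/C=N\NC(=O)C2=C(Cl)c3ccccc3CCC2)cc1`: 2300 nM
- compound 2 `COc1cc(/C=N\NC(=O)C2=C(Cl)c3ccccc3CCC2)cc(OC)c1OC`: 8200 nM

Both compounds share one core and differ only in the aromatic ring attached through the hydrazone linker. In a functional assay on HeLa cells (Homo sapiens) for inhibition, read by sulforhodamine B assay, with a stated time of 48 h (a higher number here means a weaker inhibitor of growth, a lower number a stronger inhibitor of growth), compound 1 gives 2300 nM, the lowest of the two numbers, so of this pair it is the stronger inhibitor of cell growth. Compound 2 gives 8200 nM in this assay, a higher number whose gap to compound 1 lies beyond the usual scatter, so the two compounds are genuinely distinguished.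

Compound 3 `O=C(N/N=C\c1ccc(Cl)cc1)C1=C(Cl)c2ccccc2CCC1` has not been measured. It differs from compound 1 in a single place: chloro in place of methyl on an aromatic carbon, in words, chloro in place of methyl on an aromatic carbon, para to a large group. Within the data shown here, no pair of measured compounds shows what this exchange does here. The leaving and entering groups are each a single heavy atom with no donors and no acceptors. The expectation is a small step, none beyond the scatter, in either direction. Compound 3 is therefore expected to give about 2200 nM in this assay, within 900 nM to 5500 nM. The estimated change a 1.0-fold lower number from compound 1 to compound 3 (0.02 log units; within the scatter) is expected to stay inside the scatter.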

Compound 3, concentration for 50% growth inhibition: 2300 nM
Compound 3: middle estimate off by 1.0-fold (0.02 log units), on the low side; the range from low to high includes it.
By their numbers in this assay, from the lowest: compounds 1 and 3 (each within the scatter of the next); then compound 2.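

In this assay, among these compounds, the change from 4-methylphenyl to 4-chlorophenyl gives no change at the digits printed from compound 1 to compound 3 (within the scatter) and this is the first reading of a single exchange, as the earlier compounds offered no such step. On this core and at this position, methyl and chloro therefore cannot be told apart by growth inhibition in HeLa cells, so the position accepts either of these two single-atom groups without a shift beyond the usual variation between repeats. No measurement at hand explains why the two groups read alike.

Going by these compounds, one exchange between two small groups says little about the position as a whole, so it remains open whether an amine, a carboxylic acid or a longer alkyl chain in the same place would keep the reading or move it. On these data alone, it also remains open whether chloro in place of methyl would read the same way on a ring that carries other groups, such as the methoxy groups of compound 2.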